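Taking the methyl off the methoxy of compound 2

This account rests on a few compounds, and the source may have more. Where it says the series, first, only, none or still open, it means among the compounds named here.

Compound 2 `COc1cc(-c2nn(-c3cccc(NC(=O)Nc4cc(C(F)(F)F)cc(C(F)(F)F)c4)c3)cc2-c2ccncc2)ccc1Cl` gives 3380 nM in a functional assay on SK-MEL-28 cells (Homo sapiens) for inhibition, read by sulforhodamine B assay, with a stated time of 48 h (on this read-out higher numbers stand for lower toxicity in this test and lower numbers for higher toxicity in this test), the lowest of the two numbers shown there. Compound 3 `COc1cc(-c2nn(-c3cccc(NC(=O)Nc4cccc(C(F)(F)F)c4)c3)cc2-c2ccncc2)ccc1Cl` gives 21100 nM in this assay. The step of a 6.2-fold higher number from compound 2 to compound 3 (0.80 log units; beyond the scatter) is a modest one and comes from a hydrogen in place of trifluoromethyl on an aromatic carbon. Compound 1 `O=C(Nc1cccc(-n2cc(-c3ccncc3)c(-c3ccc(Cl)c(O)c3)n2)c1)Nc1cccc(C(F)(F)F)c1` is reported only as a limit in this assay, namely > 32500 nM.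

Compound 4 `O=C(Nc1cccc(-n2cc(-c3ccncc3)c(-c3ccc(Cl)c(O)c3)n2)c1)Nc1cc(C(F)(F)F)cc(C(F)(F)F)c1` differs from compound 2 by hydrogen in place of methyl on an oxygen on an aromatic ring. Going by the values given here, only one measured step bears on this change, and it runs in the opposite direction: an at least 1.5-fold lower number from compound 1 to compound 3 (0.18 log units; that floor lies within the scatter), a floor that stays within the scatter since compound 1 sits at the limit of > 32500 nM in this assay, at which 1 of the 3 values shown sits. Read backwards, it suggests that removing the methyl may raise the number, towards lower toxicity, by an amount that need not clear the scatter. Compound 4 is therefore expected to give about 6000 nM in this assay, with a likely range from 2500 nM to 20000 nM. The expected step is a 1.8-fold higher number from compound 2 to compound 4 (0.25 log units; within the scatter), at most a small move and possibly none beyond the scatter.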

Compound 4, concentration lethal to 50% of the cells: 3090 nM
Compound 4: middle estimate off by 1.9-fold (0.29 log units), on the high side, and the stated range covers the measured number.
By their numbers in this assay, from the lowest: compounds 4 and 2 (each within the scatter of the next); then compound 3. At a limit, above all of these: compound 1.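

Exchanging methoxy for hydroxy on the core of compound 2 gives no step beyond the scatter in this assay, with a 1.1-fold lower number from compound 2 to compound 4 (0.04 log units; within the scatter). This gives a reading of the change between two numbers, where the earlier step rested on a limit, although a comparison of the two cores stays out of reach: the same change on two cores in this assay, an at least 1.5-fold lower number (0.18 log units; that floor lies within the scatter) from compound 1 to compound 3 and a 1.1-fold higher number (0.04 log units; within the scatter) from compound 4 to compound 2; the limit leaves it open whether they differ The added trifluoromethyl also matters with hydroxy in place, with an at least 10-fold lower number from compound 1 to compound 4 (1.02 log units; beyond the scatter), pointing the same way as with methoxy: the same change on two cores in this assay, a 6.2-fold higher number (0.80 log units; beyond the scatter) from compound 2 to compound 3 and an at least 10-fold higher number (1.02 log units; beyond the scatter) from compound 4 to compound 1; the limit leaves it open whether they differ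

Going by these compounds, compound 1 is reported only as a limit, > 32500 nM, and the true size of the steps that start from it remains unknown. The compounds shown leave open whether an ethoxy group or an amine on that aromatic carbon, in place of methoxy or hydroxy, would give a number beyond the scatter of these.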